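The source may hold more compounds than are shown below. What is called first, only, known or untested is meant among the compounds shown, and "the series" means these compounds.

Measured so far:
compound 1 `COC(=O)c1cc(-c2cccc(NC(=O)c3ccc(/C=C/C(=O)c4ccccc4)cc3)c2)on1` — > 50 ug/mL
compound 2 `COC(=O)c1cc(-c2cccc(NC(=O)c3ccc(/C=C/C(=O)c4ccccc4OC)cc3)c2)on1` — > 40 ug/mL
compound 3 `COC(=O)c1cc(-c2cccc(NC(=O)c3ccc(/C=C/C(=O)c4ccc(F)cc4)cc3)c2)on1` — > 20 ug/mL

In an ADME assay on Vero cells (Chlorocebus sabaeus) for cytotoxicity, read by MTT assay, with a stated time of 72 h (a lower number here means that less compound is tolerated, a higher number that more compound is tolerated), compound 1 gives > 50 ug/mL, which is a limit of the assay and not a number. Compound 2 likewise reaches only a limit, > 40 ug/mL. Compound 3 also stops at a limit, > 20 ug/mL. Since every value shown is a limit (the limit of > 20 ug/mL in this assay, at which 1 of the 3 values shown sits, (the limit of > 40 ug/mL in this assay, at which 1 of the 3 values shown sits), (the limit of > 50 ug/mL in this assay, at which 1 of the 3 values shown sits)), the steps a step that the two limits leave unreadable from compound 1 to compound 2 and a step that the two limits leave unreadable from compound 1 to compound 3 cannot be read for size, and the same holds for a step that the two limits leave unreadable from compound 2 to compound 3. None of them shows a change in tolerated concentration; compound 1 stands at a limit with no numbered neighbour to rank it against.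

Compound 4 `CCCOc1ccc(C(=O)/C=C/c2ccc(C(=O)Nc3cccc(-c4cc(C(=O)OC)no4)c3)cc2)cc1` differs from compound 1 by propoxy in place of hydrogen on an aromatic carbon. Among the measured compounds shown here, no measured step covers a propoxy group; the nearest comparisons, a methoxy and a fluoro entering the benzoyl of compound 1 in compound 2 and compound 3, both ended at limits. The expectation for compound 4 in this assay is therefore a step of a number no higher from compound 1 to compound 4 (the limit leaves the size open) of no readable size, most likely again reported as a limit. Compound 4 is estimated at 50 ug/mL, within 25 ug/mL to 100 ug/mL.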

Compound 4, half-maximal cytotoxic concentration: > 40 ug/mL
Compound 4 ended at the assay's limit; the forecaster's own chance of this, stated with the estimate: 70%; the middle value is on the limit's open side.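

Compound 4 also stops at a limit in this assay, so its steps from compound 1, compound 2 and compound 3 cannot be read for size. The compounds shown leave open where the tolerated concentration of each of the four compounds actually lies, and whether any change on the benzoyl shifts it.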